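The source may hold more compounds than are shown below. What is called first, only, known or untested is meant among the compounds shown, and "the series" means these compounds.

In a physicochemical assay for permeability, using PAMPA (on this read-out lower numbers stand for lower permeability and higher numbers for higher permeability), compound 1 `Cc1oc(-c2ccccc2Cl)nc1CN1CCC(C(=O)NCCCN2C[C@H](C)C[C@H](C)C2)CC1` gives 352 10^-6 cm/s and compound 2 `Cc1oc(-c2c(F)cccc2F)nc1CN1CCC(C(=O)NCCCN2C[C@H](C)C[C@H](C)C2)CC1` gives 82.4 10^-6 cm/s. Compound 3 `Cc1oc(-c2c(Br)cccc2Br)nc1CN1CCC(C(=O)NCCCN2C[C@H](C)C[C@H](C)C2)CC1` gives only a limit, < 1 10^-6 cm/s, and it stands lowest of the three. Compound 4 `Cc1cccc(-c2nc(CN3CCC(C(=O)NCCCN4C[C@H](C)C[C@H](C)C4)CC3)c(C)o2)c1` differs from compound 3 in one place: 3-methylphenyl in place of 2,6-dibromophenyl on an aromatic carbon. Among the measured compounds shown here, no measured compound carries the 3-methylphenyl, so the evidence is indirect. Two large steps lead into the 2,6-dibromophenyl, an at least 350-fold lower number from compound 1 to compound 3 (2.54 log units; beyond the scatter) and an at least 82-fold lower number from compound 2 to compound 3 (1.91 log units; beyond the scatter), while the step between the other two groups is modest, a 4.3-fold lower number from compound 1 to compound 2 (0.63 log units; beyond the scatter). Leaving the 2,6-dibromophenyl is therefore expected to bring a large rise, with the expected step being an at least 150-fold higher number from compound 3 to compound 4 (2.17 log units; beyond the scatter). Compound 4 is estimated at 150 10^-6 cm/s, with an expected range from 30 10^-6 cm/s to 500 10^-6 cm/s.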

Compound 4, apparent permeability: 279 10^-6 cm/s
The estimate for compound 4 lay 1.9-fold (0.27 log units) below the measured number, and the stated range covers the measured number.
By their numbers in this assay, from the lowest: compound 2; then compounds 4 and 1 (each within the scatter of the next). At a limit, below all of these: compound 3.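

In this assay, the 3-methylphenyl, which carries no halogen, reads level with the 2-chlorophenyl (a 1.3-fold lower number from compound 1 to compound 4 (0.10 log units; within the scatter)), so a halogen at this position is not needed for a high number. The same group stands clear of the 2,6-difluorophenyl (a 3.4-fold higher number from compound 2 to compound 4 (0.53 log units; beyond the scatter)) and far from the 2,6-dibromophenyl (an at least 270-fold higher number from compound 3 to compound 4 (2.44 log units; beyond the scatter)). Compound 3 gives a limit and not a number: the limit of < 1 10^-6 cm/s in this assay, at which 1 of the 4 values shown sits.

On these data alone, how a 2-bromophenyl or a 2-methylphenyl would read remains open. So does whether an amine or a carboxylic acid on the phenyl would keep the number high.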